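A few compounds are considered here, and "the series" means these few. Any claim that something is new, unique, unknown or untested is made for them only; others in the source may bear on it.

Working notes on a short series of acylguanidines sharing one core.

Compound 1 `Cc1nc(N)sc1CCCN/C(N)=N/C(=O)NC(c1ccccc1)C(C)C` is measured in a functional assay on Right cardiac atrium for agonist activity at histamine H2 receptor (Cavia porcellus), with a stated time of 30 min, in the presence of a further agent that is not named here (a lower number here means a smaller maximal response, a higher number a larger maximal response), where compound 1 reaches 1.04. For the measured compounds named here, the only other measured member, compound 2 `CCCCCCNC(=O)/N=C(\N)NCCCc1sc(N)nc1C`, carries a hexyl chain on the urea nitrogen in place of the branched benzylic substituent; in this assay compound 2 reaches 0.95. The two numbers lie within the scatter of each other, so compound 1 cannot be set apart from compound 2 on this read-out: both behave as full agonists relative to the reference.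

Compound 3 `CCC(NC(=O)/N=C(\N)NCCCc1sc(N)nc1C)c1ccccc1` has not yet been measured. Relative to compound 1 the change is hydrogen in place of methyl on a saturated chain carbon bound to two saturated chain carbons. Going by the values given here, no measured pair of this series differs by a single change, so no measured step of comparable kind is available for guidance. Given that compound 1 and compound 2 both sit near the full response despite quite different substituents on the urea nitrogen, the step from compound 1 to compound 3 in this assay is expected to be small, with no direction beyond the scatter: a number 0.040 lower from compound 1 to compound 3 (within the scatter). For compound 3 in this assay the expected value is 1, within a range from 0.85 to 1.1.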

Compound 3, intrinsic activity: the largest response reached, as a fraction of the reference agonist's: 0.93
For compound 3 the middle estimate is 0.070 above the measured one; measured number inside the range.
By their numbers in this assay, from the lowest: compounds 3, 2 and 1 (each within the scatter of the next, the first and the last beyond it).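

In this assay, for the compounds shown here, the change from isopropyl to ethyl, hydrogen in place of methyl on a saturated chain carbon bound to two saturated chain carbons, gives the first single-place step: a number 0.11 lower from compound 1 to compound 3 (beyond the scatter) is the reading. This place is therefore not silent on the maximal response, since the loss of one carbon, with no ring, hydrogen-bond donor, hydrogen-bond acceptor or net charge involved, gives a modest step that can be read beyond the scatter. Nothing available bears on the reason for this step.

From the compounds shown here alone, the finding rests on one pair, so it remains open whether a still shorter methyl group would extend the step in the same direction or whether a longer chain such as butyl would give a larger maximal response. Also open, going by these compounds, is how a hydroxyl group or an amine would read in this place, and whether the step from isopropyl to ethyl would hold if the phenyl ring on the same substituent were replaced by a pyridine ring.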